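This account rests on a few compounds, and the source may have more. Where it says the series, first, only, none or still open, it means among the compounds named here.

Measured so far (a functional assay on SMMC-7721 cells (Homo sapiens) for cytotoxicity, read by MTT assay, with a stated time of 72 h; on this read-out higher numbers stand for weaker inhibition and lower numbers for stronger inhibition)
- Compound 1 (`CC(=O)c1ccc(NC(=O)CSC(=S)N[C@H]2CCOC2=O)cc1`) reaches only a limit of the assay (> 128000 nM).
- Compound 2 (`O=C(CSC(=S)N[C@H]1CCOC1=O)Nc1ccc(C(=O)/C=C/c2ccc(Cl)cc2)cc1`) reaches only a limit of the assay (> 128000 nM).
- Compound 3 (`O=C(CSC(=S)N[C@H]1CCOC1=O)Nc1ccc(C(=O)/C=C/c2ccc(Br)cc2)cc1`) gives a number (18000 nM).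

Compound 3 alone gives a true number, while the others show (the limit of > 128000 nM in this assay, at which 2 of the 3 values shown sit). Compound 4 (`O=C(CSC(=S)N[C@H]1CCOC1=O)Nc1ccc(C(=O)/C=C/c2cccc(Cl)c2)cc1`) differs from compound 3 in one group, with 3-chlorophenyl in place of 4-bromophenyl (3-chlorophenyl in place of 4-bromophenyl on a double-bonded chain carbon bound to a double-bonded chain carbon). The closest guide is an at least 7.1-fold lower number from compound 2 to compound 3 (0.85 log units; beyond the scatter), which came with bromo in place of chloro. Less direct are an at least 7.1-fold lower number from compound 1 to compound 3 (0.85 log units; beyond the scatter) and a step that the two limits leave unreadable from compound 1 to compound 2. Going by the values given here, compound 4 carries chloro again, though as 3-chlorophenyl, which no measured compound has, so a modest move toward higher numbers is expected, possibly reaching the limit. The expected change is a 3.1-fold higher number from compound 3 to compound 4 (0.49 log units; beyond the scatter). For compound 4 the estimated value is 55000 nM, with an expected range from 16000 nM to 128000 nM.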

Compound 4, half-maximal inhibitory concentration: 39100 nM
For compound 4 the middle estimate is 1.4-fold (0.15 log units) above the measured one, within the range that was stated.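

In this assay compound 2 gives only a limit, > 128000 nM. Even so, 3-chlorophenyl in place of 4-chlorophenyl gives an at least 3.2-fold lower number from compound 2 to compound 4 (0.51 log units; beyond the scatter), so a chloro-bearing ring can give a readable number here, and 2-(3-chlorophenyl)ethenyl in place of methyl gives an at least 3.2-fold lower number from compound 1 to compound 4 (0.51 log units; beyond the scatter). Replacing 4-bromophenyl with 3-chlorophenyl still gives a 2.2-fold higher number from compound 3 to compound 4 (0.34 log units; beyond the scatter), so bromo at the 4-position keeps the lowest number shown.

That last step changes both the halogen and its place, so the two effects stay unseparated. From the compounds shown here alone, how 3-bromophenyl, or a phenyl ring carrying an amine or a carboxylic acid, would read remains open.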